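This account rests on a few compounds, and the source may have more. Where it says the series, first, only, none or still open, it means among the compounds named here.

Measured compounds:
compound 1, `O=C(NCc1cc(C(F)(F)F)nn1-c1cccc(Cl)c1)Nc1cccc2[nH]ncc12`: 0.9 nM
compound 2, `CC(C)(C)c1cc(CNC(=O)Nc2cccc3[nH]ncc23)n(-c2cccc(Cl)c2)n1`: 0.6 nM
compound 3, `Cn1ncc2c(NC(=O)NCc3cc(C(F)(F)F)nn3-c3ccc(C(F)(F)F)cc3)cccc21`: 3.9 nM

All three were tested in an assay on CHO-K1 cells for antagonist activity at transient receptor potential cation channel subfamily V member 1 (Homo sapiens), read by FLIPR and calcium flux, with a stated time of 6 min; on this read-out higher numbers stand for weaker inhibition and lower numbers for stronger inhibition. Compound 1 gives 0.9 nM and compound 2 gives 0.6 nM, the two being separated by a single change, (tert-butyl in place of trifluoromethyl on an aromatic carbon), which produced a 1.5-fold lower number from compound 1 to compound 2 (0.18 log units; within the scatter). Compound 3 stands apart from both, giving 3.9 nM in this assay, the highest of the three numbers; how its core differs from that of compound 1 is not broken down here.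

Compound 4, `Cn1ncc2c(NC(=O)NCc3cc(C(F)(F)F)nn3-c3ccc(C(C)(C)C)cc3)cccc21`, has not yet been measured. It is related to compound 3 by tert-butyl in place of trifluoromethyl on an aromatic carbon. Within the data shown here, this is the same kind of change as the one from compound 1 to compound 2, but not the same: in the earlier pair it sits on an aromatic carbon of a five-membered aromatic ring with 2 nitrogen, next to the ring nitrogen, whereas here it sits on an aromatic carbon of a six-membered aromatic ring of carbon only, para to a large group.

Since the earlier step of this kind was a 1.5-fold lower number from compound 1 to compound 2 (0.18 log units; within the scatter) and stayed within the scatter, compound 4 is expected to lie close to compound 3 in this assay, with a small step of about a 1.3-fold lower number from compound 3 to compound 4 (0.11 log units; within the scatter). The estimate for compound 4 is 3 nM, with a plausible range from 1 nM to 10 nM.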

Compound 4, inhibition constant: 13.2 nM
For compound 4 the middle estimate is 4.4-fold (0.64 log units) below the measured one; the measured number lies above the stated range.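

In this assay, tert-butyl in place of trifluoromethyl on the six-membered aromatic ring of carbon only gave a 3.4-fold higher number from compound 3 to compound 4 (0.53 log units; beyond the scatter), so the near-silent result of the earlier swap did not carry over to this pair. Set side by side, the two outcomes differ, and they do so in direction as well as in size: the same change on two cores in this assay, a 1.5-fold lower number (0.18 log units; within the scatter) from compound 1 to compound 2 and a 3.4-fold higher number (0.53 log units; beyond the scatter) from compound 3 to compound 4, 5.1-fold (0.71 log units) apart, beyond the scatter of two such steps. This shows that, in this series, the result of the swap on one scaffold cannot simply be transferred to another, but it does not show what separates the two steps, since the pairs differ both in their cores and in the ring that carries the change, and two pairs give no rule for any further core.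

The compounds shown leave open whether the same swap on the five-membered aromatic ring, with the rest of compound 3 kept, would follow the step from compound 1 to compound 2 or the one from compound 3 to compound 4. They also leave open how other groups on the phenyl ring of compound 3, such as a methyl, a chlorine or an amine, would read in this assay.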